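Moving the chlorine on a thiourea anilide ring

A few compounds are considered here, and "the series" means these few. Any claim that something is new, unique, unknown or untested is made for them only; others in the source may bear on it.

Four close relatives share one core, differing only in the aromatic ring carried on the thiourea nitrogen. Compound 1 `COc1cc2c(cc1OC)C(=O)C(CC1CCN(C(=S)Nc3ccccc3)CC1)C2` carries a plain phenyl ring, compound 2 `COc1cc2c(cc1OC)C(=O)C(CC1CCN(C(=S)Nc3cccc(C)c3)CC1)C2` a 3-methylphenyl ring, compound 3 `COc1cc2c(cc1OC)C(=O)C(CC1CCN(C(=S)Nc3cccc(Cl)c3)CC1)C2` a 3-chlorophenyl ring, and compound 4 `COc1cc2c(cc1OC)C(=O)C(CC1CCN(C(=S)Nc3ccc(Cl)cc3)CC1)C2` a 4-chlorophenyl ring. The activity of interest is a functional assay on the whole organism (strain Swiss albino) with Mus musculus as the target, with a stated time of 0.5 h; a higher number here means that more compound is needed for the effect, a lower number that less compound is needed. In this assay compound 1 gives 100 mg/kg. For compound 2 the result in this assay is "not determined" (no result reported), and for compound 3 it is likewise "not determined" (no result reported), so compound 3 stands without a number to anchor it; the only figure at hand comes from compound 1.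

The change from compound 3 to compound 4 is 4-chlorophenyl in place of 3-chlorophenyl on an amide-type nitrogen. With no measured step between any two of these compounds, nothing shows how this assay responds to such a change, and the expectation is no shift beyond the usual scatter, in either direction. On that basis compound 4 is estimated at 100 mg/kg, with a plausible range from 30 mg/kg to 300 mg/kg.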

Compound 4, minimum effective dose: 100 mg/kg
The estimate for compound 4 equals the measured number at the digits printed; the measured number falls inside the stated range.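

In this assay the series now has its first readable step, no change at the digits printed from compound 1 to compound 4 (within the scatter), for chloro in place of hydrogen on an aromatic carbon of the ring on the thiourea nitrogen. The 4-chlorophenyl ring and the plain phenyl ring therefore read alike here, so this ring can carry a chlorine in that arrangement without a shift beyond the usual scatter. Nothing at hand explains this result.

Compound 2 and compound 3 have no number, so the steps involving them cannot be read, and the swap of 3-chlorophenyl for 4-chlorophenyl stays unresolved. Also open, on these data alone, is how this assay would respond to a phenyl ring bearing an amine or a carboxylic acid, or to a longer alkyl chain on that nitrogen in place of the ring.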